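A few compounds are considered here, and "the series" means these few. Any claim that something is new, unique, unknown or untested is made for them only; others in the source may bear on it.

Compound 1 `COC(=O)c1cccc(Nc2ncnc3ccc(NC(=O)Nc4ccc(CN5CCN(C)CC5)cc4)cc23)c1` in a functional assay on A549 cells (Homo sapiens) for antiproliferative activity, read by MTT assay, with a stated time of 72 h (on this read-out higher numbers stand for weaker inhibition and lower numbers for stronger inhibition), reaches only the limit > 10000 nM. Compound 2 `CCN(CC)Cc1ccc(NC(=O)Nc2ccc3ncnc(Nc4cccc(C(F)(F)F)c4)c3c2)cc1` gives 2070 nM in this assay . Compound 3 `C[C@@H](Nc1ncnc2ccc(NC(=O)Nc3ccc(CN4CCN(C)CC4)cc3)cc12)c1ccccc1` reaches only the limit > 10000 nM in this assay .

Among the measured compounds shown here, compound 2 therefore stands as the only compound with a number in this assay; the other two sit at a limit, namely (the limit of > 10000 nM in this assay, at which 2 of the 3 values shown sit). For the measured compounds named here, the one step measured between compounds differing in a single place, from compound 1 to compound 3, reads a step that the two limits leave unreadable from compound 1 to compound 3, so nothing can be taken from it.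

Compound 4 `COc1ccc(NC(=O)Nc2ccc3ncnc(Nc4cccc(C(F)(F)F)c4)c3c2)cc1` differs from compound 2 in one place: methoxy in place of (diethylamino)methyl on an aromatic carbon. Going by the values given here, no measured step touches this change, and the only measured step is unreadable, so the expectation rests on the value of compound 2 alone, with no direction given by the data. Compound 4 is therefore expected to lie near compound 2, at an estimated 3000 nM, with a range from 900 nM to 12000 nM. The step expected from compound 2 to compound 4 is a 1.4-fold higher number from compound 2 to compound 4 (0.16 log units; within the scatter), that is, none beyond the scatter.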

Compound 4, half-maximal inhibitory concentration: 9470 nM
For compound 4 the middle estimate is 3.2-fold (0.50 log units) below the measured one; the measured number falls inside the stated range.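

Among the compounds shown here, with the shared core otherwise unchanged, the change on this aromatic carbon, para to a large group, gives the first readable step in this assay: a 4.6-fold higher number from compound 2 to compound 4 (0.66 log units; beyond the scatter). The position is therefore not indifferent to what it carries, and on this one pair (diethylamino)methyl goes with stronger inhibition than methoxy. Compound 1 and compound 3 give no number to set beside this, each being only a limit: the limit of > 10000 nM in this assay, at which 2 of the 4 values shown sit.

A single pair cannot separate the loss of the amine nitrogen from the loss of the larger chain, and it gives no reason for the step. From the compounds shown here alone, how a morpholinomethyl group, which keeps an amine on a methylene, or a plain hydroxyl on this carbon would read against these two groups remains open.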